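Capping the hydroxy group of compound 2

A few compounds are considered here, and "the series" means these few. Any claim that something is new, unique, unknown or untested is made for them only; others in the source may bear on it.

Values in a functional assay on SW480 cells (Homo sapiens) for antiproliferative activity, read by MTT assay, with a stated time of 48 h (on this read-out higher numbers stand for weaker inhibition and lower numbers for stronger inhibition), are as follows.
- compound 1 `CCCCCCCC[C@H](CCO)n1cnc2c(Cl)ncnc21` gives 320 nM
- compound 2 `CCCCCCCCC[C@H](CCO)n1cnc2c(Cl)ncnc21` gives 1630 nM
- compound 3 `CCCCCCCCC[C@@H](CCO)n1cnc2c(Cl)ncnc21` gives 3620 nM

Compound 2 holds the second highest of the three numbers, with compound 1 lower and compound 3 higher. Compound 4 (`CCCCCCCCC[C@H](CCOS(C)(=O)=O)n1cnc2c(Cl)ncnc21`) departs from compound 2 by one change (methylsulfonyl in place of hydrogen on an oxygen on a saturated carbon): methylsulfonyl in place of hydrogen on an oxygen on a saturated carbon, so that hydroxy becomes (methylsulfonyl)oxy.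

Two measured steps lie nearby. One (a 5.1-fold higher number from compound 1 to compound 2 (0.71 log units; beyond the scatter)) is methyl in place of hydrogen on a saturated chain carbon. The other (a 2.2-fold higher number from compound 2 to compound 3 (0.35 log units; beyond the scatter)) comes down to the fact that compounds 2 and 3 differ only in the configuration as drawn alone. Neither touches the oxygen, so neither gives a direction for compound 4. They show only how far two small edits moved the number here, and both steps were modest. The new change is a bigger edit than either, so the range must stay wide.

In this assay no step beyond the scatter is expected in either direction, and the expected step (a 1.1-fold lower number from compound 2 to compound 4 (0.04 log units; within the scatter)) reflects that. Compound 4 is estimated at 1500 nM within an expected range from 400 nM to 6000 nM overall.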

Compound 4, half-maximal inhibitory concentration: 9720 nM
Compound 4: the middle estimate sits 6.5-fold (0.81 log units) below what was measured; the whole stated range lies below it.
By their numbers in this assay, from the lowest: compound 1; then compound 2; then compound 3; then compound 4.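

In this assay, replacing the hydrogen of the hydroxy group with methylsulfonyl gives a 6.0-fold higher number from compound 2 to compound 4 (0.78 log units; beyond the scatter) and so weakens inhibition, which shows that this oxygen on the saturated carbon is a place where a change registers in the assay. Compound 4 still gives a measured value of 9720 nM in this assay, so the hydroxy hydrogen can be lost and a number can still be read. The compounds shown offer no explanation for this step, and the one fact on hand, about configuration, does not bear on the new group.

A single example cannot tell whether the number rose with the loss of the hydroxy hydrogen or with the arrival of the methylsulfonyl group, and a simple methyl ether or an acetate ester on the same oxygen would help to separate those two readings. Also open, from the compounds shown here alone, is how an amine would behave in place of the hydroxy group, and whether the same 2-((methylsulfonyl)oxy)ethyl change would move the number similarly on the core of compound 1 or of compound 3.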